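Acrylonitrile series: pyrrole to bromofuran swap, growth inhibition

A few compounds are considered here, and "the series" means these few. Any claim that something is new, unique, unknown or untested is made for them only; others in the source may bear on it.

Measured so far in a functional assay on BE(2)-C cells (Homo sapiens) for inhibition, read by MTT assay, with a stated time of 72 h; a lower number here means a stronger inhibitor of growth, a higher number a weaker inhibitor of growth:
compound 1 `N#C/C(=C\c1c(F)c(F)c(F)c(F)c1F)C(=O)c1ccc[nH]1` gives 14000 nM
compound 2 `N#C/C(=C\c1c(F)c(F)c(F)c(F)c1F)C(=O)c1c[nH]c2ccccc12` gives 10000 nM
compound 3 `COc1ccc(CNC(=O)/C(C#N)=C/c2ccc[nH]2)cc1` gives 47000 nM

Compound 3 gives the highest number of the three; compound 1 stands nearest with its lower number and compound 2 furthest, both gaps beyond the scatter. The next compound, compound 4 `COc1ccc(CNC(=O)/C(C#N)=C/c2ccc(Br)o2)cc1`, carries 5-bromofuran-2-yl in place of 1H-pyrrol-2-yl on a double-bonded chain carbon bound to a double-bonded chain carbon. Among the measured compounds shown here, no measured pair shows this change, so its size cannot be read from the data. The expected step, a 2.4-fold lower number from compound 3 to compound 4 (0.37 log units; beyond the scatter), is modest and toward a lower number, though a step within the scatter or the other way would not surprise. On that basis compound 4 is estimated at 20000 nM in this assay, with an expected range from 5000 nM to 80000 nM.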

Compound 4, concentration for 50% growth inhibition: 13000 nM
Beside the measured number, compound 4's estimate is 1.5-fold (0.19 log units) above it, and the stated range covers the measured number.
By their numbers in this assay, from the lowest: compounds 2, 4 and 1 (each within the scatter of the next); then compound 3.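

In this assay, placing 5-bromofuran-2-yl in place of 1H-pyrrol-2-yl on a double-bonded chain carbon bound to a double-bonded chain carbon gives a 3.6-fold lower number from compound 3 to compound 4 (0.56 log units; beyond the scatter) in this amide pair. This position therefore responds to a change of ring, and the number falls although the entering group has no hydrogen-bond donor. No measurement at hand explains this step.

The step does not separate the contribution of the bromine from that of the furan oxygen. As far as these compounds go, how an unsubstituted furan-2-yl or a 5-bromothiophen-2-yl group would stand remains open.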